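Removing the whole side group from the pyridinone series

This account rests on a few compounds, and the source may have more. Where it says the series, first, only, none or still open, it means among the compounds named here.

Measured so far:
compound 1 `CCCCc1ccc(CNC(=O)Nc2ccccc2)c(=O)n1Cc1ccc(-c2ccccc2-c2nn[nH]n2)cc1`: 30 nM
compound 2 `CCCCc1ccc(CN(C)S(=O)(=O)c2ccc(C)cc2)c(=O)n1Cc1ccc(-c2ccccc2-c2nn[nH]n2)cc1`: 8 nM

In a functional assay (aorta) for antagonist activity, with Oryctolagus cuniculus as the target (a higher number here means a weaker inhibitor, a lower number a stronger inhibitor), compound 2 gives 8 nM, the lowest of the two numbers, with compound 1 as its nearest neighbour, a 3.8-fold lower number from compound 1 to compound 2 (0.57 log units; beyond the scatter). Compound 3 `CCCCc1ccc(C)c(=O)n1Cc1ccc(-c2ccccc2-c2nn[nH]n2)cc1` differs from compound 2 by hydrogen in place of methyl((4-methylphenyl)sulfonyl)amino on a saturated chain carbon bound to an aromatic carbon. Going by the values given here, the one measured step bears on it only loosely: it swaps one side group for another, whereas here the group is removed altogether. Compound 3 is therefore expected to give a clearly higher number, with the step of a 31-fold higher number from compound 2 to compound 3 (1.49 log units; beyond the scatter) expected. Compound 3 is estimated at 250 nM, in the range 40 nM to 1500 nM.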

Compound 3, half-maximal inhibitory concentration: 7 nM
Beside the measured number, compound 3's estimate is 36-fold (1.55 log units) above it; measured number below the stated range.
By their numbers in this assay, from the lowest: compounds 3 and 2 (each within the scatter of the next); then compound 1.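

In this assay, hydrogen in place of methyl((4-methylphenyl)sulfonyl)amino on this saturated chain carbon gives a 1.1-fold lower number from compound 2 to compound 3 (0.06 log units; within the scatter) and so shows that the low number does not depend on that side group. Hydrogen in place of (phenylcarbamoyl)amino gives a 4.3-fold lower number from compound 1 to compound 3 (0.63 log units; beyond the scatter) and so shows that this side group, unlike the sulfonyl one, goes with a higher number than no side group at all. No measurement shown here accounts for this difference.

The compounds shown leave open how an amine or a carboxylic acid would behave on this carbon. They also leave open whether a simple longer chain there would match compound 3.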